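Replacing cyano on the core of compound 1

The compounds below may be only part of what the source reports. "The series", "measured", "known", "first", "only" and "open" are said of these compounds alone.

Compound 1 `CCN1CCc2c(sc(NC(=O)Nc3ccc(Cl)cc3)c2C#N)C1`: > 25000 nM
Compound 2 `CCCN1CCc2c(sc(NC(=O)Nc3ccc(Cl)cc3)c2C(N)=O)C1`: 3500 nM

In a functional assay (strain AB) with Danio rerio as the target, read by microscopy, with a stated time of 1 h (on this read-out lower numbers stand for an effect already at smaller amounts and higher numbers for an effect only at larger amounts of compound), the entry for compound 1, > 25000 nM, is a limit and not a number. Compound 3 `CCN1CCc2c(sc(NC(=O)Nc3ccc(Cl)cc3)c2C(=O)NCCO)C1` carries (2-hydroxyethyl)carbamoyl in place of cyano on an aromatic carbon. Among the compounds with values here, no measured step isolates this change. Compound 2 also carries an amide rather than cyano, though it differs elsewhere too, and it gives the measured 3500 nM, which suggests a number for compound 3 rather than a limit. A step towards lower numbers in this assay, beyond the scatter, is expected: an at least 3.1-fold lower number from compound 1 to compound 3 (0.49 log units; beyond the scatter). The estimated value for compound 3 is 8000 nM, with an expected range of 2000 nM to 25000 nM.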

Compound 3, half-maximal effective concentration: 9400 nM
Compound 3: the middle estimate sits 1.2-fold (0.07 log units) below what was measured, and the stated range covers the measured number.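

In this assay, (2-hydroxyethyl)carbamoyl in place of cyano on an aromatic carbon gives an at least 2.6-fold lower number from compound 1 to compound 3 (0.42 log units; beyond the scatter), the only step shown that isolates a change at this position. On the core of compound 1, this position therefore accepts the larger amide group and still gives a measured number. The step remains a lower bound because compound 1 stands at a limit: the limit of > 25000 nM in this assay, at which 1 of the 3 values shown sits.

As far as these compounds go, whether the amide alone or its terminal hydroxyl drives the step remains open. A primary carboxamide, a carboxylic acid or a longer chain ending in an amine on the core of compound 1 would help separate these.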